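Bromine to Iodine on the Anilino Ring

The source may report more compounds than this note shows. Statements on the series, on what has been measured and on what is new or still open speak of the compounds shown alone.

Measured compounds:
Compound 1, `O=C1C=C(N2CCC2)C(=O)c2c1nc1n2[C@H]2OC[C@@H](O)[C@H]2OC1`, in a functional assay on MGC-803 cells (Homo sapiens) for inhibition, read by sulforhodamine B assay (on this read-out lower numbers stand for stronger inhibition and higher numbers for weaker inhibition), gives only a limit, > 16000 nM.
Compound 2, `O=C1C=C(Nc2ccc(Br)cc2)C(=O)c2c1nc1n2[C@H]2OC[C@@H](O)[C@H]2OC1`, in this assay gives 1010 nM.
Compound 3, `COc1cccc(NC2=CC(=O)c3c(nc4n3[C@H]3OC[C@@H](O)[C@H]3OC4)C2=O)c1`, in this assay gives 1790 nM.

Compound 2 and compound 3 cannot be told apart on these numbers, since their values lie within the usual scatter of each other. The result for compound 1 is a limit of the assay, (the limit of > 16000 nM in this assay, at which 1 of the 3 values shown sits), not a number.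

Compound 4, `O=C1C=C(Nc2ccc(I)cc2)C(=O)c2c1nc1n2[C@H]2OC[C@@H](O)[C@H]2OC1`, differs from compound 2 by iodo in place of bromo on an aromatic carbon

Among the measured compounds shown here, the only measured step, an at least 15-fold lower number from compound 1 to compound 2 (1.19 log units; beyond the scatter), concerns a different change and offers no direct guide to swapping one halogen for another on the aromatic carbon. For the measured compounds named here, no measured pair shows what such a swap does here, so the estimate rests on compound 2 itself. Compound 4 is therefore expected to sit close to compound 2, with a step of a 1.1-fold lower number from compound 2 to compound 4 (0.05 log units; within the scatter), that is, no change beyond the scatter. The expected value for compound 4 in this assay is 900 nM, within a range from 400 nM to 2500 nM.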

Compound 4, half-maximal inhibitory concentration: 1400 nM
For compound 4 the middle estimate is 1.6-fold (0.19 log units) below the measured one; low and high end bracket the measured number.
By their numbers in this assay, from the lowest: compounds 2, 4 and 3 (each within the scatter of the next). At a limit, above all of these: compound 1.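

In this assay, among the compounds shown here, iodo in place of bromo on the aromatic carbon para to a large group gives a 1.4-fold higher number from compound 2 to compound 4 (0.14 log units; within the scatter), so the two halogens cannot be told apart at this position, which no earlier pair could show. (4-Iodophenyl)amino in place of azetidin-1-yl gives an at least 11-fold lower number from compound 1 to compound 4 (1.05 log units; beyond the scatter), so the large step first seen with (4-bromophenyl)amino recurs with a second halogen. Compound 1 stands at a limit rather than a number, so both of these steps have an open end: the limit of > 16000 nM in this assay, at which 1 of the 4 values shown sits.

The compounds shown leave open whether this insensitivity extends beyond bromo and iodo, for instance to chloro or fluoro on the same aromatic carbon. They also leave open what a carboxylic acid, an amine or plain hydrogen would do there.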